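Chloro to Trifluoromethyl on the Aryl Tetrazole

The source may report more compounds than this note shows. Statements on the series, on what has been measured and on what is new or still open speak of the compounds shown alone.

Measured compounds:
- compound 1, `Cc1cc(NC(=O)Cn2nnc(-c3ccccc3)n2)n(C2CCS(=O)(=O)CC2)n1`: > 10000 nM
- compound 2, `Cc1nc(-c2ccccc2)c(NC(=O)Cn2nnc(-c3ccccc3)n2)s1`: "not active" (no number reported)
- compound 3, `Cc1cc(NC(=O)Cn2nnc(-c3cccc(Cl)c3)n2)n(C2CCCCC2)n1`: 300 nM

Three compounds have been examined in an assay on HEK293 cells for activation of Kir3.1/Kir3.2 (Homo sapiens), read by thallium flux; a lower number here means that less compound is needed, a higher number that more compound is needed for the effect. Compound 1 reaches only the limit of the assay, > 10000 nM, and so carries no number. Compound 2 is reported without a number at all, as "not active" (no number reported). Within the data shown here, that leaves compound 3, with 300 nM, as the only compound of the set with a measured concentration in this assay, and it stands alone. The one further entry, that of compound 1, sits at the limit of > 10000 nM in this assay, at which 1 of the 3 values shown sits. The remaining entry, that of compound 2, carries no number.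

Compound 4, `Cc1cc(NC(=O)Cn2nnc(-c3cccc(C(F)(F)F)c3)n2)n(C2CCCCC2)n1`, has not yet been measured. It differs from compound 3 in one place: trifluoromethyl in place of chloro on an aromatic carbon. The chloro leaves and the trifluoromethyl enters on an aromatic carbon of a six-membered aromatic ring of carbon only, meta to a large group.

Among the measured compounds shown here, no step between measured compounds is available to guide the size of this change. The expectation is that the step from compound 3 to compound 4 in this assay, a 1.3-fold higher number from compound 3 to compound 4 (0.12 log units; within the scatter), stays within the usual scatter, with no clear direction. Compound 4 is therefore estimated at 400 nM, in a range from 150 nM to 1200 nM.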

Compound 4, half-maximal effective concentration: 183 nM
The estimate for compound 4 lay 2.2-fold (0.34 log units) above the measured number, within the range that was stated.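

In this assay, among these compounds, replacing chloro with trifluoromethyl gives a 1.6-fold lower number from compound 3 to compound 4 (0.21 log units; within the scatter) and so provides the first comparison in the set between two compounds that differ in one place. On an aromatic carbon of the six-membered aromatic ring of carbon only, meta to a large group, a substituent of four heavy atoms thus stands in for one of a single heavy atom, and the two compounds cannot be told apart in this read-out, something that compound 3 on its own could not show. Nothing measured in the set speaks to why these two groups give values so close to each other.

The compounds shown leave open whether a nitrile, a methoxy group or an amine at this same place would keep the concentration needed in this range, or whether one of them would move it beyond the scatter. Among the compounds shown here, they also leave open what plain hydrogen at this place would give with the rest of compound 3 kept, since no compound with an unsubstituted ring shares the rest of that structure.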